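Swapping the amide aryl group in a cytotoxicity series

This account rests on a few compounds, and the source may have more. Where it says the series, first, only, none or still open, it means among the compounds named here.

Measured compounds:
- Compound 1, `COc1cc2c(Nc3nc4ccc(C(=O)Nc5c(C)cc(C)cc5C)cc4s3)ncnc2cc1OCCCN1CCC(C)CC1`: 5600 nM
- Compound 2, `COc1cc2c(Nc3nc4ccc(C(=O)Nc5c(C)cccc5C)cc4s3)ncnc2cc1OCCCN1CCCCC1`: 14700 nM
- Compound 3, `COc1cc2c(Nc3nc4ccc(C(=O)Nc5c(C)cccc5Cl)cc4s3)ncnc2cc1OCCCN1CCCCC1`: 8600 nM

These three compounds share one core and differ only in the aryl group on the amide nitrogen and in the ring at the end of the side chain. In a functional assay on U-937 cells (Homo sapiens) for cytotoxicity, read by WST assay, with a stated time of 72 h (on this read-out higher numbers stand for weaker inhibition and lower numbers for stronger inhibition), compound 3 stands second highest of the three numbers; its nearest neighbour is compound 1, and its furthest is compound 2, and both gaps are within the scatter. Among the measured compounds shown here, the one measured step that touches the amide aryl group, a 1.7-fold lower number from compound 2 to compound 3 (0.23 log units; within the scatter), is also within the scatter.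

Compound 4, `COc1cc2c(Nc3nc4ccc(C(=O)Nc5c(C)cc(C)cc5C)cc4s3)ncnc2cc1OCCCN1CCCCC1`, has not yet been measured. The change from compound 3 is 2,4,6-trimethylphenyl in place of 2-chloro-6-methylphenyl on an amide-type nitrogen. The step from compound 2 to compound 3 shows that exchanging chloro and methyl at this group hardly moved the number. Compound 1 carries the same 2,4,6-trimethylphenyl group that enters here and gives 5600 nM, close to the value of compound 3. So no step beyond the scatter is expected, and the estimate for compound 4 is 8000 nM, with a range from 3500 nM to 18000 nM, amounting to an expected step of a 1.1-fold lower number from compound 3 to compound 4 (0.03 log units; within the scatter).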

Compound 4, half-maximal inhibitory concentration: 12200 nM
For compound 4 the middle estimate is 1.5-fold (0.18 log units) below the measured one; measured number inside the range.
By their numbers in this assay, from the lowest: compounds 1, 3, 4 and 2 (each within the scatter of the next, the first and the last beyond it).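

In this assay the amide aryl group has now been varied three ways with the same unsubstituted ring at the end of the side chain, and no two of the three separate: the exchange of 2-chloro-6-methylphenyl for 2,4,6-trimethylphenyl gives (a 1.4-fold higher number from compound 3 to compound 4 (0.15 log units; within the scatter)) and methyl in place of hydrogen on an aromatic carbon gives (a 1.2-fold lower number from compound 2 to compound 4 (0.08 log units; within the scatter)), both within the scatter. The chlorine can therefore leave this group, and a third methyl can enter it, without a change in the number that can be told from the usual scatter. Among the compounds shown here, the only step here beyond the scatter lies at the other end of the molecule: hydrogen in place of methyl on a saturated ring carbon of the side chain gives a modest rise (a 2.2-fold higher number from compound 1 to compound 4 (0.34 log units; beyond the scatter)), so in this single pair the lower number of compound 1 goes with that ring methyl and not with the amide aryl group.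

From the compounds shown here alone, whether an amine or a carboxylic acid on the amide aryl ring, or an ethyl group in place of the ring methyl, would move the number stays open. Nothing besides these cell numbers is at hand to explain them.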